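The source may report more compounds than this note shows. Statements on the series, on what has been measured and on what is new or still open speak of the compounds shown alone.

Working notes on the series. Compound 3 `Cn1ncc(Cl)c1-c1cc(C(=O)N[C@@H]2CN[C@H](CC(=O)NCCO)C[C@H]2c2ccc(Cl)c(Cl)c2)oc1Cl` stands lowest of the three numbers in an assay for inhibition of RAC-alpha serine/threonine-protein kinase (Homo sapiens), read by HTRF, with a stated time of 1 h (on this read-out lower numbers stand for stronger inhibition and higher numbers for weaker inhibition), where compound 3 gives 1.41 nM. Its nearest neighbour is compound 1 `Cn1ncc(Cl)c1-c1cc(C(=O)N[C@@H]2CN[C@H](CC(=O)O)C[C@H]2c2ccc(Cl)c(Cl)c2)oc1Cl`, for which this assay returns 1.94 nM; the step of a 1.4-fold lower number from compound 1 to compound 3 (0.14 log units; within the scatter) lies within the scatter, so the two cannot be ordered. Furthest is compound 2 `Cn1ncc(Cl)c1-c1cc(C(=O)N[C@@H]2CN[C@H](CCN3CCCC3)C[C@H]2c2ccc(Cl)c(Cl)c2)oc1Cl`, with 6.41 nM in this assay; the step of a 4.5-fold lower number from compound 2 to compound 3 (0.66 log units; beyond the scatter) is beyond the scatter, as is a 3.3-fold higher number from compound 1 to compound 2 (0.52 log units; beyond the scatter).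

Compound 4 `CCC[C@@H]1C[C@@H](c2ccc(Cl)c(Cl)c2)[C@H](NC(=O)c2cc(-c3c(Cl)cnn3C)c(Cl)o2)CN1` is not yet measured. Relative to compound 3 the change is ethyl in place of (2-hydroxyethyl)carbamoyl on a saturated chain carbon bound to a saturated ring carbon. The step that bears most directly on it is a 4.5-fold lower number from compound 2 to compound 3 (0.66 log units; beyond the scatter), since compound 2 also carries a group with no hydrogen-bond donor or acceptor on the saturated chain carbon bound to a saturated ring carbon, and that exchange cost a modest amount. The step of a 1.4-fold lower number from compound 1 to compound 3 (0.14 log units; within the scatter) shows that carboxy and (2-hydroxyethyl)carbamoyl are interchangeable within the scatter. Ethyl carries neither a charge nor any donor or acceptor, and no measured compound tests exactly that; a modest weakening, in the direction of a higher number, is expected, of the size a 5.7-fold higher number from compound 3 to compound 4 (0.75 log units; beyond the scatter). Compound 4 is therefore estimated at 8 nM, with a range from 3 nM to 25 nM.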

Compound 4, half-maximal inhibitory concentration: 10.4 nM
For compound 4 the middle estimate is 1.3-fold (0.11 log units) below the measured one, within the range that was stated.
By their numbers in this assay, from the lowest: compounds 3 and 1 (each within the scatter of the next); then compounds 2 and 4 (each within the scatter of the next).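

Ethyl on a saturated chain carbon bound to a saturated ring carbon gives a 7.4-fold higher number from compound 3 to compound 4 (0.87 log units; beyond the scatter) against (2-hydroxyethyl)carbamoyl and a 5.4-fold higher number from compound 1 to compound 4 (0.73 log units; beyond the scatter) against carboxy, so a plain alkyl end with 0 hydrogen-bond donors and 0 hydrogen-bond acceptors separates from both of these groups, a contrast the earlier compounds showed only with pyrrolidin-1-yl. The step of a 1.6-fold higher number from compound 2 to compound 4 (0.21 log units; within the scatter) lies within the scatter, so methyl and pyrrolidin-1-yl on a saturated chain carbon, two bonds along the chain from a saturated ring carbon, cannot be ordered, and the two compounds without a carbonyl in this group, compound 2 and compound 4, sit together at the higher numbers. No measurement is available here that accounts for this split between the two pairs.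

The compounds shown leave open whether a primary amine or a simple hydroxyl at the end of the same chain, or a longer chain of plain carbon atoms, would fall with compound 4 or with compound 3. They also leave open whether a carbonyl alone is enough, as a methyl ketone or a primary amide in this place would test.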